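Methoxy in place of nitro on compound 1

The source may report more compounds than this note shows. Statements on the series, on what has been measured and on what is new or still open speak of the compounds shown alone.

Compound 1 `C/C=C/C(=O)N(Cc1ccc(OC)c([N+](=O)[O-])c1)c1cc(OC)c(OC)c(OC)c1` gives 670 nM
Compound 2 `COc1ccc(CNc2cc(OC)c(OC)c(OC)c2)cc1[N+](=O)[O-]` gives 18200 nM

In a functional assay on HCT-116 cells (Homo sapiens) for inhibition, read by MTT assay, with a stated time of 48 h (a higher number here means a weaker inhibitor, a lower number a stronger inhibitor), compound 1 gives 670 nM and holds the lower of the two numbers. The change to compound 3 `C/C=C/C(=O)N(Cc1ccc(OC)c(OC)c1)c1cc(OC)c(OC)c(OC)c1` is methoxy in place of nitro on an aromatic carbon and puts methoxy in place of nitro on an aromatic carbon. For the measured compounds named here, the one measured step of a 27-fold higher number from compound 1 to compound 2 (1.43 log units; beyond the scatter) is large, but it removes the (prop-1-en-1-yl)carbonyl and keeps the nitro, so it does not bear directly on this change. Going by the values given here, no measured step touches the nitro, so no step beyond the scatter is firmly expected. The step expected in this assay is a 1.2-fold higher number from compound 1 to compound 3 (0.08 log units; within the scatter) by estimate, with its direction uncertain. Compound 3 is estimated at 800 nM with an expected low of 200 nM and high of 3000 nM as its range.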

Compound 3, half-maximal inhibitory concentration: 32800 nM
Beside the measured number, compound 3's estimate is 41-fold (1.61 log units) below it; the measured number lies above the stated range.
By their numbers in this assay, from the lowest: compound 1; then compounds 2 and 3 (each within the scatter of the next).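

In this assay, methoxy in place of nitro on this aromatic carbon brings a 49-fold higher number from compound 1 to compound 3 (1.69 log units; beyond the scatter), so the position is not indifferent to the group it carries. The earlier step changed only the (prop-1-en-1-yl)carbonyl on the nitrogen; this one shows that keeping that group does not by itself preserve the number of compound 1. No evidence is available to account for this step. Still open, going by these compounds, is whether the step reflects losing the nitro or gaining the methoxy. An amine, a nitrile or a plain hydrogen on this carbon could separate the two.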